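The source may report more compounds than this note shows. Statements on the series, on what has been measured and on what is new or still open speak of the compounds shown alone.

Compound 2, `CCC1(Cc2ccccc2)OS(=O)(=O)C=C1OCC=C(C)C`, is the compound that is tolerated best among the two measured: in an ADME assay on HEL cells (Homo sapiens) for cytotoxicity, with a stated time of 3 days (a higher number here means that more compound is tolerated, a lower number that less compound is tolerated), compound 2 gives 112000 nM, which stands as the highest of the two numbers. Among the measured compounds shown here, its nearest neighbour, compound 1, `CCC1(Cc2ccccc2)OS(=O)(=O)C=C1OCc1ccccc1Cl`, gives 38000 nM in this assay, and the only step recorded, a 2.9-fold higher number from compound 1 to compound 2 (0.47 log units; beyond the scatter), separates the two. The unmeasured compound 3, `CCC1(Cc2ccccc2)OS(=O)(=O)C=C1OC(=O)c1ccccc1`, carries benzoyl in place of 3-methylbut-2-en-1-yl on an oxygen on an unsaturated carbon. The step from compound 1 to compound 2 bears on this change only in part, since an aromatic ring left and one now enters again, though through a carbonyl rather than a saturated chain carbon; that step was modest in size, and a modest move in the opposite direction, that is a lower number, is expected for compound 3, as a 1.9-fold lower number from compound 2 to compound 3 (0.27 log units; within the scatter). Compound 3 is therefore estimated at 60000 nM in this assay, within a range from 20000 nM to 150000 nM.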

Compound 3, half-maximal cytotoxic concentration: > 200000 nM
Compound 3: a limit, no number; the forecaster's own chance of this, stated with the estimate: 15%; at least 3.3-fold (0.52 log units) between middle value and limit.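

In this assay compound 3 gives no number, only a limit: the limit of > 200000 nM in this assay, at which 1 of the 3 values shown sits. Benzoyl on this oxygen, in place of 3-methylbut-2-en-1-yl, gives an at least 1.7-fold higher number from compound 2 to compound 3 (0.25 log units; that floor lies within the scatter), so the change shows no loss of tolerance, although this floor alone does not set the two compounds apart. The separation from the 2-chlorobenzyl compound is clearer, at an at least 5.2-fold higher number from compound 1 to compound 3 (0.72 log units; beyond the scatter), which shows that a six-membered aromatic ring at this place can occur with either the lowest number or the limit.

Going by these compounds, the true value of compound 3 remains unknown, as does whether the carbonyl or the absence of chlorine matters more in the gap from compound 1. The compounds shown also leave open how an unsubstituted benzyl, an amine or a longer chain on this oxygen would behave.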